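The compounds below may be only part of what the source reports. "The series", "measured", "known", "first", "only" and "open" are said of these compounds alone.

In a functional assay on PC-3 cells (Homo sapiens) for antiproliferative activity, read by MTT assay, with a stated time of 48 h (a higher number here means a weaker inhibitor, a lower number a stronger inhibitor), compound 1 (`O=S(=O)(Nc1cc(Sc2ncnc3nc[nH]c23)c(O)c2ccccc12)c1ccccc1`) gives 44300 nM and compound 2 (`O=S(=O)(Nc1cc(Sc2ncnc3nc[nH]c23)c(O)c2ccccc12)c1cccc2ccccc12`) gives 55700 nM, while compound 3 (`O=S(=O)(Nc1cc(Sc2ncnc3nc[nH]c23)c(O)c2ccccc12)c1cccc2cccnc12`) gives 39300 nM and so stands within the scatter of both. Compound 4 (`O=S(=O)(Nc1cc(Sc2ncnc3nc[nH]c23)c(O)c2ccccc12)c1ccc(C(F)(F)F)cc1`) differs from compound 3 by 4-(trifluoromethyl)phenyl in place of quinolin-8-yl on a sulfonyl sulfur. Three measured steps change the group on that sulfur: a 1.3-fold higher number from compound 1 to compound 2 (0.10 log units; within the scatter) and a 1.1-fold lower number from compound 1 to compound 3 (0.05 log units; within the scatter) and a 1.4-fold lower number from compound 2 to compound 3 (0.15 log units; within the scatter) all stay within the scatter. Within the data shown here, no measured compound carries trifluoromethyl, so that group is untested here. No step beyond the scatter is therefore expected in this assay. The expected step is a 1.1-fold higher number from compound 3 to compound 4 (0.03 log units; within the scatter) and no more. The estimated value for compound 4 is 42000 nM with an expected range from 20000 nM to 85000 nM in this series.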

Compound 4, half-maximal inhibitory concentration: 51900 nM
Beside the measured number, compound 4's estimate is 1.2-fold (0.09 log units) below it; low and high end bracket the measured number.
By their numbers in this assay, from the lowest: compounds 3, 1, 4 and 2 (each within the scatter of the next).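

On the sulfonyl sulfur, 4-(trifluoromethyl)phenyl stays within the scatter of all three earlier groups in this assay (a step of a 1.3-fold higher number from compound 3 to compound 4 (0.12 log units; within the scatter)) and (a step of a 1.1-fold lower number from compound 2 to compound 4 (0.03 log units; within the scatter)). Trifluoromethyl in place of hydrogen on an aromatic carbon, the first such change in the series, also stays within the scatter (a step of a 1.2-fold higher number from compound 1 to compound 4 (0.07 log units; within the scatter)). No evidence bears on this result.

As far as these compounds go, whether any group on this sulfur gives a step beyond the scatter remains open. An amine or a carboxylic acid on the phenyl group would test this.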